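The compounds below may be only part of what the source reports. "The series", "measured", "known", "first", "only" and "open" are said of these compounds alone.

Working notes on the series. In a functional assay on LM7 cells (Homo sapiens) for antiproliferative activity, read by MTT assay, with a stated time of 72 h (on this read-out higher numbers stand for weaker inhibition and lower numbers for stronger inhibition), compound 3 `CC(C)N(C(=S)SCc1cc(=O)c2ccc(Cl)cc2o1)C(C)C` reaches only (the limit of > 30000 nM in this assay, at which 1 of the 3 values shown sits), which is a limit of the assay and not a number, recorded as > 30000 nM. Compound 1 `O=c1cc(CSC(=S)N2CCCCC2)oc2cc(Cl)ccc12` carries piperidin-1-yl in place of diisopropylamino on a thiocarbonyl carbon and in this assay compound 1 gives 13800 nM; the step is an at least 2.1-fold lower number from compound 3 to compound 1 (0.33 log units; beyond the scatter). Compound 2 `COc1ccc2oc(CSC(=S)N(C(C)C)C(C)C)cc(=O)c2c1` gives 19100 nM in this assay, with compound 1 as its nearest neighbour within the scatter. How the core of compound 2 differs from that of compound 3 is not broken down here. Compound 4 `COc1ccc2oc(CSC(=S)N3CCCCC3)cc(=O)c2c1` is not yet measured in this assay. It relates to compound 2 exactly as compound 1 relates to compound 3, namely by piperidin-1-yl in place of diisopropylamino on a thiocarbonyl carbon, the place being described in the same words in both pairs, so this is the same change made a second time. With the first occurrence starting from a limit, its true size is open, and a somewhat smaller step is expected here, a 1.9-fold lower number from compound 2 to compound 4 (0.28 log units; within the scatter). This rests on compound 2 at 19100 nM. Compound 4 is therefore estimated at 10000 nM in this assay, with a range of 5000 nM to 25000 nM.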

Compound 4, half-maximal inhibitory concentration: 5000 nM
Beside the measured number, compound 4's estimate is 2.0-fold (0.30 log units) above it, and the stated range covers the measured number.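

In this assay, going by these compounds, piperidin-1-yl in place of diisopropylamino on a thiocarbonyl carbon gives a 3.8-fold lower number from compound 2 to compound 4 (0.58 log units; beyond the scatter), so the change lowers the number on the core of compound 2, and the direction seen on the core of compound 1 carries over to this second core: the same change on two cores in this assay, an at least 2.1-fold lower number (0.33 log units; beyond the scatter) from compound 3 to compound 1 and a 3.8-fold lower number (0.58 log units; beyond the scatter) from compound 2 to compound 4; the limit leaves it open whether they differ Compound 3 is recorded at > 30000 nM, which is a limit of the assay and not a number, so the size of the first step remains unknown. The two steps therefore show a shared direction on two cores only; they do not show that the step keeps its size from one core to the other, or that it would hold on any further core.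

On these data alone, it remains open whether morpholin-4-yl, pyrrolidin-1-yl or diethylamino on the same thiocarbonyl carbon would follow piperidin-1-yl or diisopropylamino on these cores. The compounds shown also leave open whether the ring of piperidin-1-yl or some other difference between the two groups accounts for the lower numbers.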